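Series Notes: Aryl Variation on the Shared Core

The compounds below may be only part of what the source reports. "The series", "measured", "known", "first", "only" and "open" are said of these compounds alone.

Measured so far:
compound 1 `CC#CC(CC(=O)O)c1ccc(OCc2ccn3cc(-c4ccc(C)cc4C)nc3c2)cc1` — 503 nM
compound 2 `CC#CC(CC(=O)O)c1ccc(OCc2ccn3cc(-c4ccc(C)cc4)nc3c2)cc1` — 618 nM
compound 3 `CC#CC(CC(=O)O)c1ccc(OCc2ccn3cc(-c4cc(F)ccc4F)nc3c2)cc1` — 639 nM

All three values come from an assay on isolated protein for agonist activity at Free fatty acid receptor 1 (Homo sapiens); a lower number here means that less compound is needed, a higher number that more compound is needed for the effect. Compound 3 gives the highest number of the three, but its steps to the others are small: a 1.0-fold higher number from compound 2 to compound 3 (0.01 log units; within the scatter) and a 1.3-fold higher number from compound 1 to compound 3 (0.10 log units; within the scatter). Also a 1.2-fold higher number from compound 1 to compound 2 (0.09 log units; within the scatter) is within the scatter. No ordering among the three can be claimed.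

Compound 4 `CC#CC(CC(=O)O)c1ccc(OCc2ccn3cc(-c4ccccc4F)nc3c2)cc1` differs from compound 3 by hydrogen in place of fluoro on an aromatic carbon. The three measured steps all change the aryl group on the shared core, and none moved this assay beyond the scatter; none bears on the same fluoro directly, but they suggest that the aryl substitution pattern is tolerated. No step beyond the scatter is therefore expected in this assay, a 1.0-fold higher number from compound 3 to compound 4 (0.01 log units; within the scatter). Compound 4 is estimated at 650 nM, range 300 nM to 1400 nM.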

Compound 4, half-maximal effective concentration: 705 nM
Estimate against measurement, compound 4: 1.1-fold (0.04 log units) below; the measured number falls inside the stated range.
By their numbers in this assay, from the lowest: compounds 1, 2, 3 and 4 (each within the scatter of the next).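

Taking out the fluoro para to a fluoro group, the change from 2,5-difluorophenyl to 2-fluorophenyl, is the first change confined to this single aromatic position, and in this assay it stays within the scatter (a 1.1-fold higher number from compound 3 to compound 4 (0.04 log units; within the scatter)). The wider aryl replacements also stay within the scatter (a 1.1-fold higher number from compound 2 to compound 4 (0.06 log units; within the scatter); a 1.4-fold higher number from compound 1 to compound 4 (0.15 log units; within the scatter)), so this fluoro is dispensable for the reading among these compounds. No supporting data bear on this result.

Still open, on these data alone, is whether the remaining fluoro can also go. Also open, as far as these compounds go, is whether an amine or a methoxy group on this aromatic ring would give a step beyond the scatter.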